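The compounds below may be only part of what the source reports. "The series", "measured", "known", "first", "only" and "open" are said of these compounds alone.

In a functional assay on NCI-H460 cells (Homo sapiens) for inhibition, read by CCK-8 assay, with a stated time of 72 h (on this read-out lower numbers stand for stronger inhibition and higher numbers for weaker inhibition), compound 1, `Nc1ccccc1NC(=O)c1ccc(CNC(=O)c2n[nH]cc2NC(=O)c2ccccc2Cl)cc1`, gives 6360 nM, and compound 2, `O=C(NO)c1ccc(CNC(=O)c2n[nH]cc2NC(=O)c2c(Cl)cccc2Cl)cc1`, gives 10600 nM. For the measured compounds named here, these are the only two measurements available, and they lie within the usual scatter of each other, so neither compound can be separated from the other on these numbers. Compound 1 therefore stands level with compound 2, and both values sit in the micromolar region.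

The next compound, compound 3, `Nc1ccccc1NC(=O)c1ccc(CNC(=O)c2n[nH]cc2NC(=O)c2ccccc2F)cc1`, keeps the core of compound 1 and alters a single substituent. The change sits ortho to a large group and turns the 2-chlorophenyl into a 2-fluorophenyl: fluoro in place of chloro on an aromatic carbon. Going by the values given here, no pair of measured compounds isolates a change of this kind, so the data give no direct guide to its size or direction. The expectation therefore starts from compound 1 at 6360 nM and assumes no shift beyond the scatter in this assay. The expected change is a 1.1-fold higher number from compound 1 to compound 3 (0.04 log units; within the scatter), an estimate with no firm direction. For compound 3 the estimated value is 7000 nM, with an expected range from 3000 nM to 16000 nM.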

Compound 3, half-maximal inhibitory concentration: 9990 nM
Compound 3: middle estimate off by 1.4-fold (0.15 log units), on the low side, and the stated range covers the measured number.
By their numbers in this assay, from the lowest: compounds 1, 3 and 2 (each within the scatter of the next).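

Read in this assay, fluoro in place of chloro on an aromatic carbon, ortho to a large group, gives a 1.6-fold higher number from compound 1 to compound 3 (0.20 log units; within the scatter). For the compounds shown here, this is the first measured pair that isolates a single change, and it shows that the 2-chlorophenyl of compound 1 and the 2-fluorophenyl of compound 3 cannot be told apart at this position in this assay, with both compounds remaining in the micromolar region. The result rests on this one pair and two halogens, and no measurement is available that explains it.

The compounds shown leave open whether any group at this position can move the number beyond the scatter, for example a hydrogen, a methyl, a methoxy, an amine or a trifluoromethyl. They also leave open whether the same exchange of chloro and fluoro would read the same way on a different core, since compound 2 differs from compound 1 in more than one place and offers no matched comparison.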